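This account rests on a few compounds, and the source may have more. Where it says the series, first, only, none or still open, it means among the compounds named here.

Of the compounds shown here, three of the same core have been tested in an assay on HEK293 cells for positive allosteric modulation of metabotropic glutamate receptor 5 (Homo sapiens), read by FLIPR, with a stated time of 1 h (a lower number here means that less compound is needed, a higher number that more compound is needed for the effect), and each returned only a limit. Compound 1 `Cc1cccc(C#Cc2nc3c(s2)C(=O)NCC3)c1` reached the limit > 10000 nM. Compound 2 `Fc1cccc(C#Cc2nc3c(s2)CN(C2CCOC2)CC3)c1` also stopped at the limit > 10000 nM. Compound 3 `O=C(C1CCC1)N1CCc2nc(C#Cc3ccccc3)sc2C1`, the starting point here, gave the limit > 10000 nM. So compound 3 stands where every value shown sits, at the limit of > 10000 nM in this assay, at which 3 of the 3 values shown sit, with no number to compare against.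

Compound 4 `N#Cc1cccc(C(=O)N2CCc3nc(C#Cc4ccccc4)sc3C2)c1` differs from compound 3 in one place: 3-cyanophenyl in place of cyclobutyl on a carbonyl carbon. With all three values at the limit, nothing measured tells how large this change acts. The estimated step of an at least 1.2-fold lower number from compound 3 to compound 4 (0.09 log units; that floor lies within the scatter) is therefore expected to be small and uncertain in direction. Compound 4 is estimated at 8000 nM, within 1000 nM to 50000 nM.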

Compound 4, half-maximal effective concentration: 71 nM
Beside the measured number, compound 4's estimate is 110-fold (2.05 log units) above it; the whole stated range lies above it.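

In this assay, the group on the carbonyl carbon turns out to matter greatly: 3-cyanophenyl in place of cyclobutyl gives an at least 140-fold lower number from compound 3 to compound 4 (2.14 log units; beyond the scatter). The earlier compounds shown here, none of which gave a number, could not show that this position responds so strongly to a change. Compound 4 alone gives a real number, while the other compounds stop at a limit: the limit of > 10000 nM in this assay, at which 3 of the 4 values shown sit.

The aromatic ring and the nitrile enter together, so the step cannot be divided between them. Plain phenyl on the carbonyl carbon would be needed to tell what the nitrile itself contributes.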